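Methoxybenzyl Variants of a Bis(trifluoromethyl)benzenesulfonamide

A few compounds are considered here, and "the series" means these few. Any claim that something is new, unique, unknown or untested is made for them only; others in the source may bear on it.

Measured compounds:
compound 1, `O=S(=O)(NCCCCNCc1ccc(Br)cc1)c1cc(C(F)(F)F)cc(C(F)(F)F)c1`, 2000 nM in a functional assay on HPAC cells (Homo sapiens) for inhibition, read by MTT assay, with a stated time of 72 h; on this read-out lower numbers stand for stronger inhibition of growth and higher numbers for weaker inhibition of growth
compound 2, `COc1cccc(CNCCCNS(=O)(=O)c2cc(C(F)(F)F)cc(C(F)(F)F)c2)c1`, 2400 nM in this assay

Compound 1 has the lowest of the two numbers recorded so far in this assay, and its nearest neighbour is compound 2, which lies within the scatter of it: a 1.2-fold higher number from compound 1 to compound 2 (0.08 log units; within the scatter). The pair therefore shows no difference that can be trusted.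

The unmeasured compound 3, `COc1ccccc1CNCCCNS(=O)(=O)c1cc(C(F)(F)F)cc(C(F)(F)F)c1`, is reached from compound 1 by (2-methoxybenzyl)amino in place of ((4-bromobenzyl)amino)methyl on a saturated chain carbon, three bonds along the chain from a sulfonamide nitrogen. This is the same kind of exchange that leads from compound 1 to compound 2, only with the methoxy group on another position of the benzyl ring. For the measured compounds named here, the one step that bears on it, from compound 1 to compound 2, stayed within the scatter. Going by the values given here, no step in this set separates the two methoxy positions, so nothing in the data points to a direction. Compound 3 is therefore expected to sit close to compound 1, with a step of a 1.2-fold higher number from compound 1 to compound 3 (0.06 log units; within the scatter) that remains within the scatter. The estimate for compound 3 in this assay is 2300 nM, with a range from 1000 nM to 5500 nM.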

Compound 3, concentration for 50% growth inhibition: 2400 nM
Compound 3: middle estimate off by 1.0-fold (0.02 log units), on the low side; low and high end bracket the measured number.
By their numbers in this assay, from the lowest: compounds 1, 2 and 3 (each within the scatter of the next).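

In this assay, for the compounds shown here, 2-methoxyphenyl in place of 3-methoxyphenyl on a saturated chain carbon bound to an amine nitrogen gives no change at the digits printed from compound 2 to compound 3 (within the scatter), the first direct comparison of the two methoxy positions, and this read-out does not separate them. The exchange of ((4-bromobenzyl)amino)methyl for (2-methoxybenzyl)amino gives a 1.2-fold higher number from compound 1 to compound 3 (0.08 log units; within the scatter), so at this place on the chain a second methoxy variant, like compound 2, stays within the scatter of compound 1. Nothing measured here bears on why these three compounds fall so close together.

The compounds shown leave open whether this flat result would hold for a benzyl group with no substituent at all, or for one carrying a carboxylic acid or a nitrile where compounds 2 and 3 carry methoxy. Going by these compounds alone, they also leave open whether the two methoxy positions would stay equally close on a longer chain, since all three values so far lie within the scatter of one another and show no trend to follow.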